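The source may hold more compounds than are shown below. What is called first, only, known or untested is meant among the compounds shown, and "the series" means these compounds.

Compound 1 (`O=C(CCl)Nc1ccc(Cn2nc(-c3ccc(Oc4ccccc4)cc3)cc2CO)cc1`) gives 400 nM in a functional assay on JeKo-1 cells (Homo sapiens) for inhibition, read by luminescence and CellTiter-Glo, with a stated time of 72 h (on this read-out higher numbers stand for weaker inhibition and lower numbers for stronger inhibition), the lowest of the two numbers shown. Compound 3 (`O=C(CCl)Nc1ccc(Cn2nc(-c3ccc(Oc4ccccc4)cc3)cc2C(=O)O)cc1`) gives 2500 nM, and the change from compound 1 to compound 3 brings a 6.3-fold higher number from compound 1 to compound 3 (0.80 log units; beyond the scatter). Compound 2 (`C/C=C/C(=O)Nc1cccc(Cn2nc(-c3ccc(Oc4ccccc4)cc3)cc2C(=O)O)c1`) reaches the limit of > 60000 nM in this assay, at which 1 of the 3 values shown sits, and so reports only a limit, > 60000 nM. Compound 4 (`C=CC(=O)Nc1ccc(Cn2nc(-c3ccc(Oc4ccccc4)cc3)cc2CO)cc1`) differs from compound 1 by vinyl in place of chloromethyl on a carbonyl carbon, which in words is vinyl in place of chloromethyl on a carbonyl carbon. No measured step touches this change: the single step shown alters a different group, and the limit of compound 2 cannot be placed against it. Compound 4 is therefore expected to stay close to compound 1, a step of a 1.3-fold higher number from compound 1 to compound 4 (0.10 log units; within the scatter), giving an estimated 500 nM, between 150 nM and 1600 nM.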

Compound 4, half-maximal inhibitory concentration: 8000 nM
The estimate for compound 4 lay 16-fold (1.20 log units) below the measured number; the whole stated range lies below it.
By their numbers in this assay, from the lowest: compound 1; then compound 3; then compound 4. At a limit, above all of these: compound 2.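

The group on the carbonyl carbon turns out to matter strongly: in this assay, vinyl in place of chloromethyl gives a 20-fold higher number from compound 1 to compound 4 (1.30 log units; beyond the scatter). Both groups count the same number of heavy atoms and neither has a ring, so a swap this small is enough to move the number well beyond the scatter. Nothing measured here explains why. On these data alone, what remains open is how a methyl group or a longer chain on that carbonyl carbon would behave. As far as these compounds go, it is also open whether the same swap has a similar effect when carboxy replaces hydroxymethyl.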